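Swapping the amide partner on a shared dihydropyridine scaffold

The source may report more compounds than this note shows. Statements on the series, on what has been measured and on what is new or still open speak of the compounds shown alone.

Measured so far:
compound 1, `CCOC(=O)C1=C(C)NC(C)=C(C(=O)OCC)C1c1ccc(OCC(=O)Nc2ccc(C)cc2)cc1`, 43.9%
compound 2, `CCOC(=O)C1=C(C)NC(C)=C(C(=O)OCC)C1c1ccc(OCC(=O)Nc2nc3ccccc3s2)cc1`, 47.7%
compound 3, `CCOC(=O)C1=C(C)NC(C)=C(C(=O)OCC)C1c1ccc(OCc2nnc(S)o2)cc1`, 42.4%

Three compounds share one core and differ only in the group carried on the chain attached to the aromatic ring oxygen. In a functional assay on the whole organism (strain Wistar) for inhibition, with Rattus norvegicus as the target, read by paw edema, with stated times of 30 min and 0.5 h, at a dose of 20 mg/kg (a lower number here means less inhibition, a higher number more inhibition at the dose given (going by the name of the read-out)), compound 2 gives 47.7%, the highest of the three numbers, yet both other compounds lie within the usual scatter of it, so no order among them can be claimed.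

The untested compound 4, `CCOC(=O)C1=C(C)NC(C)=C(C(=O)OCC)C1c1ccc(OCC(=O)n2nc(C)cc2C)cc1`, is reached from compound 2 by one change: 3,5-dimethyl-1H-pyrazol-1-yl in place of (1,3-benzothiazol-2-yl)amino on a carbonyl carbon.

Going by the values given here, two measured steps bear on this. The change at the same place from compound 1 to compound 2 gave a number 3.8 percentage points higher from compound 1 to compound 2 (within the scatter), and the change from compound 2 to compound 3, which also removes the amide nitrogen and its hydrogen, gave a number 5.3 percentage points lower from compound 2 to compound 3 (within the scatter). Both stay within the scatter, so the group on this chain has so far made no difference that can be trusted. Compound 4 is therefore expected to show no step beyond the scatter, a number 3.7 percentage points lower from compound 2 to compound 4 (within the scatter). Compound 4 is estimated at 44%, in the range 33% to 55%.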

Compound 4, a percentage reported as inhibition, in the whole organism at one dose (the size of the read-out at that dose, not a potency): 13.7%
Compound 4: the middle estimate sits 30.3 percentage points above what was measured, outside the stated range (below it).
By their numbers in this assay, from the lowest: compound 4; then compounds 3, 1 and 2 (each within the scatter of the next).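

The group on this chain does matter after all. In this assay, placing 3,5-dimethyl-1H-pyrazol-1-yl on the carbonyl carbon gives a number 34 percentage points lower from compound 2 to compound 4 (beyond the scatter), and the same group in place of (4-methylphenyl)amino gives a number 30.2 percentage points lower from compound 1 to compound 4 (beyond the scatter), so the earlier swaps, which all stayed within the scatter, had not revealed how much this position can change the result. The 5-sulfanyl-1,3,4-oxadiazol-2-yl group also lacks the amide nitrogen and its hydrogen, yet moving from it to (3,5-dimethyl-1H-pyrazol-1-yl)carbonyl gives a number 28.7 percentage points lower from compound 3 to compound 4 (beyond the scatter), so the absence of that hydrogen alone does not go with the loss. No measurement shown here explains the fall.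

Still open, on these data alone, is whether the loss follows the pyrazole ring itself, its methyl groups, or the attachment of a ring nitrogen directly to the carbonyl carbon. An unsubstituted 1H-pyrazol-1-yl group or a piperidin-1-yl group on the same carbonyl carbon would help separate these possibilities.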